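Trimming one methoxy from a coumarin-linked dienone

The source may report more compounds than this note shows. Statements on the series, on what has been measured and on what is new or still open speak of the compounds shown alone.

Measured so far:
compound 1, `COc1cc(/C=C/C(=O)/C=C/c2cc(OC)c(OC)c(OC)c2)ccc1OCc1cn(CCCOc2cc(=O)oc3ccccc23)nn1`: 79%
compound 2, `COc1cc(/C=C/C(=O)/C=C/c2ccccc2)ccc1OCc1cn(CCCCCOc2cc(=O)oc3ccccc23)nn1`: 26%

Of the compounds shown here, two have been tested in a functional assay on THP-1 cells (Homo sapiens) for inhibition, read by sulforhodamine B assay, with a stated time of 48 h, tested at 50 uM; on this read-out lower numbers stand for less inhibition of growth and higher numbers for more inhibition of growth at the one concentration tested. Compound 1 stands highest of the two numbers, giving 79%; compound 2 is the only other, and its value of 26% lies far lower, beyond the scatter. Compound 2 differs from compound 1 in more than one place, so no single step can be read from that pair.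

Compound 3, `COc1ccc(/C=C/C(=O)/C=C/c2ccc(OCc3cn(CCCOc4cc(=O)oc5ccccc45)nn3)c(OC)c2)cc1OC`, has not been measured. It differs from compound 1 in one place: hydrogen in place of methoxy on an aromatic carbon, which, cut one bond further out, reads 3,4,5-trimethoxyphenyl to 3,4-dimethoxyphenyl. Because compound 2 gives only 26% while compound 1 gives 79%, it is expected that removing one methoxy lowers the number somewhat in this assay, by a step of about a number 19 percentage points lower from compound 1 to compound 3 (beyond the scatter). Compound 3 is therefore estimated at 60%, within a range from 35% to 80%.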

Compound 3, percent growth inhibition at one concentration: 73%
Estimate against measurement, compound 3: 13 percentage points below; low and high end bracket the measured number.
By their numbers in this assay, from the lowest: compound 2; then compounds 3 and 1 (each within the scatter of the next).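

In this assay, hydrogen in place of methoxy on an aromatic carbon gives a number 6 percentage points lower from compound 1 to compound 3 (within the scatter). Going by these compounds alone, this is the first reading of a single change: at this place, ortho to a methoxy group, the 3,4,5-trimethoxyphenyl group can give way to 3,4-dimethoxyphenyl with no shift beyond the scatter at the one concentration tested. Nothing available explains this result or bears on it.

Going by these compounds, it remains open whether an amine or a carboxylic acid on this same aromatic carbon would leave the number as little moved as hydrogen does. Also open, on these data alone, is whether either methoxy group of the 3,4-dimethoxyphenyl group could be replaced by hydrogen with a similarly small step.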